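Cytotoxicity limit from 4-bromophenyl to 4-nitrophenyl

A few compounds are considered here, and "the series" means these few. Any claim that something is new, unique, unknown or untested is made for them only; others in the source may bear on it.

In an ADME assay on MDCK cells (Canis lupus familiaris) for cytotoxicity (a higher number here means that more compound is tolerated, a lower number that less compound is tolerated), compound 1 (`CC(=O)Nc1ccc2oc(-c3ccnc(C(=O)N4CCN(C(c5ccc(F)cc5)c5nnn(C)n5)CC4)c3)nc2c1`) gives > 50000 nM, which is a limit of the assay and not a number. Compound 2 (`CC(=O)Nc1ccc2oc(-c3ccnc(C(=O)N4CCN(C(c5ccc(Br)cc5)c5nnn(C)n5)CC4)c3)nc2c1`) gives > 50000 nM, which is also a limit and not a number. Among the measured compounds shown here, compound 2 therefore has no exact position, and the series so far stands at the limit of > 50000 nM in this assay, at which 2 of the 2 values shown sit. For the measured compounds named here, the only measured change, bromo in place of fluoro on an aromatic carbon, is a step that the two limits leave unreadable from compound 1 to compound 2. It offers no size to carry forward, so no step beyond the scatter is expected in this assay. Compound 3 (`CC(=O)Nc1ccc2oc(-c3ccnc(C(=O)N4CCN(C(c5ccc([N+](=O)[O-])cc5)c5nnn(C)n5)CC4)c3)nc2c1`) carries nitro in place of bromo on an aromatic carbon, para to a large group (nitro in place of bromo on an aromatic carbon). The expected change is a number no higher from compound 2 to compound 3 (the limit leaves the size open). Compound 3 is estimated at 50000 nM, with an expected range of 25000 nM to 100000 nM.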

Compound 3, half-maximal cytotoxic concentration: > 50000 nM
Compound 3 ended at the assay's limit (the forecaster's own chance of this, stated with the estimate: 85%); the middle value lies on the limit itself.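

In this assay no step among compound 1, compound 2 and compound 3 can be read, with all three values being limits and not numbers: the limit of > 50000 nM in this assay, at which 3 of the 3 values shown sit.

Left open: whether compound 1, compound 2 and compound 3 differ at all in half-maximal cytotoxic concentration, and what that concentration is for each.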